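The source may hold more compounds than are shown below. What is called first, only, known or untested is meant among the compounds shown, and "the series" means these compounds.

Compound 1 `CCCCCCOc1ccc(-n2cnnc2)cc1` is the reference point of the series. Among the measured compounds shown here, in a functional assay on the whole organism (strain C57B/6) with Mus musculus as the target, in the maximal electroshock model (on this read-out lower numbers stand for an effect already at smaller amounts and higher numbers for an effect only at larger amounts of compound), compound 1 gives 9.8 mg/kg, the only plain number among the three values at hand. Compound 2 `CCCCCCCc1nncn1-c1ccc(OCCCCCC)cc1` reaches only a limit in this assay, > 40 mg/kg. Compound 3 `CCCCCCCCCc1nncn1-c1ccc(OCCCCCC)cc1` likewise reaches only a limit, > 40 mg/kg. Both of these sit at the limit of > 40 mg/kg in this assay, at which 2 of the 3 values shown sit. The steps away from compound 1 read an at least 4.0-fold higher number from compound 1 to compound 2 (0.61 log units; beyond the scatter) and an at least 4.0-fold higher number from compound 1 to compound 3 (0.61 log units; beyond the scatter). The step between the two substituted compounds, a step that the two limits leave unreadable from compound 2 to compound 3, is not readable.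

Compound 4 `CCCCCCOc1ccc(-n2cnnc2Cc2ccccc2)cc1` is not yet measured. Its difference from compound 1: benzyl in place of hydrogen on an aromatic carbon. The two measured steps that bear on it are the ones from compound 1 onward, where heptyl or nonyl entered at the same place. Both ran to higher numbers beyond the scatter and ended at a limit. A benzyl entering at that place is therefore expected to raise the number as well, with a fair chance that this assay again reports only a limit rather than a number. For compound 4 the expected step is a 3.1-fold higher number from compound 1 to compound 4 (0.49 log units; beyond the scatter). The estimate for compound 4 is 30 mg/kg, with a range from 12 mg/kg to 80 mg/kg.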

Compound 4, dose for half-maximal effect: 19 mg/kg
Compound 4: the middle estimate sits 1.6-fold (0.20 log units) above what was measured, within the range that was stated.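

The aromatic carbon between two ring nitrogen atoms accepts a large group without a readable cost in this assay: benzyl in place of hydrogen gives a 1.9-fold higher number from compound 1 to compound 4 (0.29 log units; within the scatter). The earlier loss at this place therefore does not hold for every large group, as benzyl separates from the two long chains with an at least 2.1-fold lower number from compound 2 to compound 4 (0.32 log units; beyond the scatter) and with an at least 2.1-fold lower number from compound 3 to compound 4 (0.32 log units; beyond the scatter). Compound 2 and compound 3 each stand at a limit, so these two steps give only a minimum size: the limit of > 40 mg/kg in this assay, at which 2 of the 4 values shown sit.

Open, going by these compounds, is whether the difference from heptyl and nonyl turns on the aromatic ring of benzyl or on the length of the group, a question that a butyl chain and a phenethyl group at the same place would separate. Also open, on these data alone, is how much room the benzyl ring leaves for further change in this assay, for instance an amine or a carboxylic acid on that ring.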